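Extending a methoxy group on a compound at the limit

A few compounds are considered here, and "the series" means these few. Any claim that something is new, unique, unknown or untested is made for them only; others in the source may bear on it.

Measured in an ADME assay on L132 cells (Homo sapiens) for cytotoxicity, read by MTT assay, with a stated time of 72 h; on this read-out higher numbers stand for weaker inhibition and lower numbers for stronger inhibition:
- compound 1 (`COC(=O)c1cc(C2=C(c3cc(OC)c(OC)c(OC)c3)C(=O)CC2O[SiH2]C(C)(C)C)ccc1OC`): > 100 ug/mL (a limit)
- compound 2 (`COc1ccc(C2=C(c3cc(OC)c(OC)c(OC)c3)C(=O)CC2O[SiH2]C(C)(C)C)cc1OC`): > 100 ug/mL (a limit)

In this assay compound 2 stands at > 100 ug/mL as a limit of the assay and not a number. Compound 3 (`COCOc1cc(C2=C(c3cc(OC)c(OC)c(OC)c3)C(=O)CC2O[SiH2]C(C)(C)C)ccc1OC`) differs from compound 2 by methoxy in place of hydrogen on a saturated chain carbon bound to an oxygen on an aromatic ring (methoxy to methoxymethoxy). Within the data shown here, the only measured step, a step that the two limits leave unreadable from compound 1 to compound 2, gives no size to carry over, and the data hold only (the limit of > 100 ug/mL in this assay, at which 2 of the 2 values shown sit). No step beyond the scatter is therefore expected, in either direction. The expected step is a number no higher from compound 2 to compound 3 (the limit leaves the size open) as an estimate. Compound 3 is estimated at 100 ug/mL (range 50 ug/mL to 200 ug/mL), and is expected most likely to be reported as a limit again.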

Compound 3, half-maximal inhibitory concentration: 32 ug/mL
For compound 3 the middle estimate is 3.1-fold (0.49 log units) above the measured one, and the stated range ends above it.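

In this assay the change from methoxy to methoxymethoxy gives an at least 3.1-fold lower number from compound 2 to compound 3 (0.49 log units; beyond the scatter) and is the first change shown to yield a readable number rather than a limit. Methoxymethoxy in place of methoxycarbonyl gives an at least 3.1-fold lower number from compound 1 to compound 3 (0.49 log units; beyond the scatter) on the same reading. On these data alone, the true size of both steps stays open, because the starting values are limits: the limit of > 100 ug/mL in this assay, at which 2 of the 3 values shown sit.

As far as these compounds go, whether the stronger inhibition needs the second oxygen of methoxymethoxy or only a longer chain remains open. A propoxy group at this place would separate the two.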